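Swapping the acid-bearing ring of a desaturase inhibitor

A few compounds are considered here, and "the series" means these few. Any claim that something is new, unique, unknown or untested is made for them only; others in the source may bear on it.

Compound 1: `O=C(O)c1cncc(-c2ccc(N3CCC(Oc4ccccc4Cl)CC3)nn2)c1` — 166 nM
Compound 2: `O=C(O)c1cncc(-c2ccc(N3CCC(Oc4cc(F)ccc4Br)CC3)nn2)c1` — 15 nM

In an assay on isolated protein for inhibition of acyl-CoA desaturase 1 (Rattus norvegicus) (a lower number here means a stronger inhibitor, a higher number a weaker inhibitor), compound 1 gives 166 nM, and compound 2 gives 15 nM. Among the measured compounds shown here, compound 2 holds the lower of the two numbers; the single measured step, an 11-fold lower number from compound 1 to compound 2 (1.04 log units; beyond the scatter), concerns only the ring on the oxygen. Compound 3 `O=C(O)c1cncc(-c2ccc(N3CCC(Oc4cc(F)ccc4Br)CC3)nn2)n1` differs from compound 2 elsewhere: 6-carboxypyrazin-2-yl in place of 5-carboxypyridin-3-yl on an aromatic carbon. For the measured compounds named here, no measured step touches that part of the molecule, so nothing here argues for a shift beyond the scatter, and compound 3 is expected to land close to compound 2, as a 1.5-fold higher number from compound 2 to compound 3 (0.17 log units; within the scatter). The estimate for compound 3 is 22 nM, with a range from 7 nM to 70 nM.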

Compound 3, half-maximal inhibitory concentration: 772 nM
Estimate against measurement, compound 3: 35-fold (1.55 log units) below, and the stated range ends below it.
By their numbers in this assay, from the lowest: compound 2; then compound 1; then compound 3.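

The acid-bearing ring turns out to be a sensitive part of the molecule in this assay: with everything else unchanged, the step is a 51-fold higher number from compound 2 to compound 3 (1.71 log units; beyond the scatter). The change looks small on paper, one ring carbon exchanged for a nitrogen, yet it takes compound 3 well beyond the scatter. Nothing available here accounts for this loss.

A benzoic acid ring in this place would show how the inhibition responds with no ring nitrogen at all. As far as these compounds go, whether the carboxylic acid itself is needed stays open, and a primary amide or a tetrazole there would test it.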